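Ring Size at the Ester: From Compound 3 to Compound 4

The compounds below may be only part of what the source reports. "The series", "measured", "known", "first", "only" and "open" are said of these compounds alone.

Measured compounds:
compound 1, `CCC(C)OC(=O)C1=C(C)NC(=O)NC1c1ccoc1`: 11%
compound 2, `CC1=C(C(=O)OC2CCCCC2)C(c2ccoc2)NC(=O)N1`: 1%
compound 3, `CC1=C(C(=O)OCC2CC2)C(c2ccoc2)NC(=O)N1`: 3%

All three share one core and differ only in the group on the oxygen next to the carbonyl group. In an assay on membranes from HeLa cells for displacement of a labelled ligand from adenosine receptor A3 (Homo sapiens), read by scintillation counting, with a stated time of 180 min, tested at 1 uM (a higher number here means more inhibition at the concentration tested (going by the name of the read-out), a lower number less inhibition), compound 1 gives 11%, compound 2 gives 1% and compound 3 gives 3%. Compound 3 holds the second highest of the three numbers; its nearest neighbour is compound 2 and its furthest is compound 1, yet every gap lies within the scatter.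

Compound 4, `CC1=C(C(=O)OCC2CCC2)C(c2ccoc2)NC(=O)N1`, is not yet measured. It differs from compound 3 in one place: cyclobutyl in place of cyclopropyl on a saturated chain carbon bound to an oxygen next to a carbonyl group. Read one bond further out, cyclopropylmethyl becomes cyclobutylmethyl.

Within the data shown here, the steps that bear on this are the ester changes already seen: a number 8 percentage points lower from compound 1 to compound 3 (within the scatter), a number 2 percentage points higher from compound 2 to compound 3 (within the scatter) and a number 10 percentage points lower from compound 1 to compound 2 (within the scatter). None of them left the scatter, so for compound 4 no step beyond the scatter is expected in this assay, and the expected change is a number 1 percentage points higher from compound 3 to compound 4 (within the scatter). Compound 4 is therefore estimated at 4%, within a range from -6% to 14%.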

Compound 4, a percentage reported as inhibition, at one concentration (the size of the read-out at that concentration, not a potency): 2%
Compound 4: middle estimate off by 2 percentage points, on the high side; the range from low to high includes it.
By their numbers in this assay, from the lowest: compounds 2, 4, 3 and 1 (each within the scatter of the next).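

In this assay, going from a three-membered to a four-membered ring on a saturated chain carbon bound to an oxygen next to a carbonyl group gives a number 1 percentage points lower from compound 3 to compound 4 (within the scatter), so this first change of ring size at this place does not separate the two compounds. The wider comparisons agree, with a number 1 percentage points higher from compound 2 to compound 4 (within the scatter) and a number 9 percentage points lower from compound 1 to compound 4 (within the scatter), so cyclobutylmethyl joins sec-butyl, cyclohexyl and cyclopropylmethyl as ester groups that this assay cannot tell apart. Nothing available here offers an explanation for this flat result.

Every ester group shown is built of carbon only, so it remains open whether an amine, a carboxylic acid or a longer chain at this place would give a step beyond the scatter. Changes to the shared core away from the ester also remain open.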